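Formyl to 2-cyanoethenyl: working notes on compound 3

This account rests on a few compounds, and the source may have more. Where it says the series, first, only, none or still open, it means among the compounds named here.

Measured so far in an ADME assay on HEK293 cells (Homo sapiens) for cytotoxicity, with a stated time of 72 h (a higher number here means that more compound is needed for the effect, a lower number that less compound is needed), with both values being limits of the assay

Compound 1 (`C=C[C@@](C)(/C=C/c1ccc(OS(=O)(=O)C(F)(F)F)cc1)CCC=C(C)C`) gives > 36600 nM
Compound 2 (`C=C[C@@](C)(/C=C/c1ccc(O)cc1)CCC=O`) gives > 36600 nM

Compound 2 stands only as a limit (> 36600 nM) and carries no number. For the measured compounds named here, the series so far shows the limit of > 36600 nM in this assay, at which 2 of the 2 values shown sit, and the two compounds cannot be ordered.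

Compound 3 (`C=C[C@@](C)(/C=C/c1ccc(O)cc1)CC/C=C/C#N`) carries 2-cyanoethenyl in place of formyl on a saturated chain carbon, three bonds along the chain from two double-bonded chain carbons.

Going by the values given here, no measured step is available to size this change. The expectation rests only on compound 2 at > 36600 nM as a limit and on compound 1 sitting at the same limit. The expected change is a number no higher from compound 2 to compound 3 (the limit leaves the size open) with no shift beyond the scatter foreseen in either direction. Compound 3 is estimated at 36600 nM within an expected range of 14000 nM to 60000 nM in this assay and may again turn out to be only a limit.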

Compound 3, half-maximal effective concentration: > 36600 nM
Compound 3: no number, only a limit (the forecaster's own chance of this, stated with the estimate: 70%); the middle value lies on the limit itself.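

The change from formyl to 2-cyanoethenyl cannot be sized, because compound 2 and compound 3 both stand only as limits in this assay and neither carries a number: the limit of > 36600 nM in this assay, at which 3 of the 3 values shown sit.

The compounds shown leave open whether any of them reaches a measurable effect in this assay and how the three would order if one did.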